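Shortening a Nitrogen-Bound Chain: From Allyl to Ethyl

The compounds below may be only part of what the source reports. "The series", "measured", "known", "first", "only" and "open" are said of these compounds alone.

Of the compounds shown here, three built on a shared core have been measured in a physicochemical assay for lipophilicity; a lower number here means a more polar compound, a higher number a more lipophilic compound. Compound 1 `C=CCn1c(=O)c(N(C)C)c(C)n(-c2ccccc2)c1=O` gives 1.98 in this assay. Compound 2 `C=CCN(CC=C)c1c(C)n(-c2ccccc2)c(=O)n(C)c1=O` gives 2.59, and compound 3 `Cc1c(NCC(C)C)c(=O)n(-c2ccccc2)c(=O)n1C` gives 1.48. Among these three numbers compound 1 stands second highest: its nearest neighbour is compound 3, which lies lower by a gap beyond the usual scatter, and its furthest is compound 2, which lies higher, again beyond the scatter.

Compound 4 `CCn1c(=O)c(N(C)C)c(C)n(-c2ccccc2)c1=O` has not been measured yet. It differs from compound 1 in one place only: methyl in place of vinyl on a saturated chain carbon bound to an aromatic nitrogen. The chain on the aromatic nitrogen thus loses one carbon and its double bond, so the whole molecule becomes slightly smaller and a little less unsaturated.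

Going by the values given here, no pair among the measured compounds differs in just this way, so the size of the step has to be judged from the change itself. Removing a carbon while the count of hydrogen-bond donors and acceptors stays unchanged is expected to lower the partition coefficient modestly, by a step of a number 0.28 log units lower from compound 1 to compound 4 (within the scatter) that is expected to sit near the edge of the scatter rather than far beyond it. On that basis compound 4 is estimated at 1.7, with a likely range from 1.3 to 2.1.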

Compound 4, partition coefficient: 2.29
Beside the measured number, compound 4's estimate is 0.59 log units below it; measured number above the stated range.
By their numbers in this assay, from the lowest: compound 3; then compound 1; then compounds 4 and 2 (each within the scatter of the next).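

Cutting the chain bound to an aromatic nitrogen from allyl to ethyl gives, in this assay, a number 0.31 log units higher from compound 1 to compound 4 (beyond the scatter), the first step here that isolates a change at this position. In this single pair, the compound with the shorter, saturated chain carries the higher number, so the loss of a carbon and a double bond did not bring the partition coefficient down, and counting carbons alone did not give the direction of this step. No separate measurement is available that could explain the direction or size of the change.

As far as these compounds go, whether a methyl, propyl or butyl chain on the same aromatic nitrogen would extend this trend, reverse it or leave the number within the scatter remains open, as a two-point comparison cannot define a trend along a series of chains. Also open, from the compounds shown here alone, is whether allyl to ethyl would give a similar step with a different amine, such as piperidine or morpholine, in place of the dimethylamino group of compound 1.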